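A Methyl Group on the Phenyl of Compound 2

The compounds below may be only part of what the source reports. "The series", "measured", "known", "first", "only" and "open" are said of these compounds alone.

Of the compounds shown here, two with a shared core have been measured in an ADME assay on C8166 cells (Homo sapiens) for cytotoxicity, read by MTT assay; on this read-out lower numbers stand for higher toxicity in this test and higher numbers for lower toxicity in this test. Compound 1 `CC(C)[C@@H](CO)n1cc(C(=O)O)c(=O)c2c(O)c(Cc3cccc(Cl)c3F)ccc21` gives 125000 nM, while compound 2 `O=C(O)c1cn(-c2ccccc2)c2ccc(Cc3cccc(Cl)c3F)c(O)c2c1=O` gives 388000 nM, the higher of the two numbers. Compound 3 `Cc1cccc(-n2cc(C(=O)O)c(=O)c3c(O)c(Cc4cccc(Cl)c4F)ccc32)c1` keeps the phenyl of compound 2 but carries methyl in place of hydrogen on an aromatic carbon, which turns phenyl into 3-methylphenyl: methyl in place of hydrogen on an aromatic carbon. For the measured compounds named here, no measured step covers this exact change, so the evidence is indirect. Going by the values given here, the only available step, a 3.1-fold higher number from compound 1 to compound 2 (0.49 log units; beyond the scatter), is modest but beyond the scatter, and it exchanges a whole group, phenyl in place of 1-(hydroxymethyl)-2-methylpropyl on an aromatic nitrogen. Since that exchange moved this assay only modestly, the addition of one methyl is expected to produce no step beyond the scatter. The expected result is a 1.2-fold lower number from compound 2 to compound 3 (0.07 log units; within the scatter). The estimate for compound 3 is 330000 nM, with an expected range from 150000 nM to 600000 nM.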

Compound 3, half-maximal cytotoxic concentration: 71600 nM
For compound 3 the middle estimate is 4.6-fold (0.66 log units) above the measured one, outside the stated range (below it).
By their numbers in this assay, from the lowest: compounds 3 and 1 (each within the scatter of the next); then compound 2.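

In this assay, one methyl on an aromatic carbon, meta to a large group, gives a 5.4-fold lower number from compound 2 to compound 3 (0.73 log units; beyond the scatter), which reads as higher toxicity in this test; this position on the phenyl therefore responds to a single added heavy atom, and the step is modest, as was the exchange of a whole group in a 3.1-fold higher number from compound 1 to compound 2 (0.49 log units; beyond the scatter). The methyl also removes the separation that compound 2 had from compound 1: a 1.7-fold lower number from compound 1 to compound 3 (0.24 log units; within the scatter), so 3-methylphenyl and 1-(hydroxymethyl)-2-methylpropyl on the aromatic nitrogen cannot be told apart in this read-out. Nothing measured here offers an explanation for the step from phenyl to 3-methylphenyl.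

The compounds shown leave open whether this shift belongs to methyl in particular or to any group at this position, a question that a chlorine, a methoxy or an amine in the same place would address. They also leave open whether methyl on another carbon of the phenyl would give a step of this kind.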